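Swapping the five-membered ring on the side chain

The compounds below may be only part of what the source reports. "The series", "measured", "known", "first", "only" and "open" are said of these compounds alone.

Compound 1 `CC(C)C(Nc1nnc[nH]1)c1ccc(-c2ccc3cccc(F)c3c2)[nH]c1=O` gives 22 nM in an assay on CHO cells for displacement of a labelled ligand from prostaglandin E2 receptor EP3 subtype (Homo sapiens), read by radioligand binding; a lower number here means a stronger inhibitor, a higher number a weaker inhibitor.
Compound 2 `CC(C)C(c1ccc(-c2ccc3cccc(F)c3c2)[nH]c1=O)N1CCN/C1=N\C#N` gives 23 nM in this assay.
Compound 3 `CC(C)C(c1ccc(-c2ccc3cccc(F)c3c2)[nH]c1=O)N1CCNC1=O` gives 9.1 nM in this assay.

All three compounds share the same core and differ only in the group on the saturated chain carbon bound to an aromatic carbon and a saturated chain carbon. Compound 3 has the lowest number of the three, with a 2.4-fold lower number from compound 1 to compound 3 (0.38 log units; beyond the scatter) and a 2.5-fold lower number from compound 2 to compound 3 (0.40 log units; beyond the scatter), both modest but beyond the scatter, while a 1.0-fold higher number from compound 1 to compound 2 (0.02 log units; within the scatter) shows that a sizeable change of that group can also leave the number unchanged.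

Compound 4 `CC(C)C(/C=C1\CCNC1=O)c1ccc(-c2ccc3cccc(F)c3c2)[nH]c1=O` is the next step from compound 3: a group of 7 heavy atoms (5 carbon, 1 nitrogen, 1 oxygen; one five-membered non-aromatic ring with 1 hetero atom) in place of a group of 6 heavy atoms (3 carbon, 2 nitrogen, 1 oxygen; one five-membered non-aromatic ring with 2 hetero atoms), on a saturated chain carbon bound to an aromatic carbon and a saturated chain carbon. Going by the values given here, no measured pair covers this particular swap. What the measured steps show is that changes at this position have moved the number by modest amounts at most, in either direction, and that compound 3 sits at the low end of the range seen so far. A modest rise, of roughly the size seen in the two steps into compound 3, is therefore the most likely outcome, and the expected step is a 1.8-fold higher number from compound 3 to compound 4 (0.25 log units; within the scatter). For compound 4 the estimate in this assay is 16 nM, with a range from 5 nM to 50 nM.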

Compound 4, inhibition constant: 2.2 nM
For compound 4 the middle estimate is 7.3-fold (0.86 log units) above the measured one; measured number outside the range, below it.
By their numbers in this assay, from the lowest: compound 4; then compound 3; then compounds 1 and 2 (each within the scatter of the next).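

Replacing 2-oxoimidazolidin-1-yl with a group whose five-membered non-aromatic ring has 1 hetero atom, and which has 2 double bonds outside aromatic rings, gives a 4.1-fold lower number from compound 3 to compound 4 (0.62 log units; beyond the scatter) in this assay. Measured against the other two groups, the same change gives a 10-fold lower number from compound 2 to compound 4 (1.02 log units; beyond the scatter) and a 10-fold lower number from compound 1 to compound 4 (1.00 log units; beyond the scatter), so this position can shift the number further than the steps among compound 1, compound 2 and compound 3 showed. The leaving and entering groups each count 1 hydrogen-bond donor and 1 hydrogen-bond acceptor, so compound 3 and compound 4 differ in their number despite matching on those counts.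

Compound 4 differs from compound 3 in its ring atoms and in its double bonds at once, and the compounds shown do not separate these two changes. Also open, from the compounds shown here alone, is how an amine, a carboxylic acid or a longer chain would behave on this saturated chain carbon bound to an aromatic carbon and a saturated chain carbon.

No supporting evidence is available to explain the fall in the number.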